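The source may hold more compounds than are shown below. What is called first, only, known or untested is meant among the compounds shown, and "the series" means these compounds.

Working notes on the series, read in an ADME assay on NHDF cells (Homo sapiens) for cytotoxicity, read by MTT assay, with a stated time of 72 h; on this read-out higher numbers stand for weaker inhibition and lower numbers for stronger inhibition. Compound 1 `COc1ccc(/C=C2\CCC/C(=C\c3cccc(OC)c3OC)C2=O)c(OC)c1` gives > 50000 nM, which is a limit of the assay and not a number. Compound 2 `COc1ccc(/C=C2\CCC/C(=C\c3cccc(OC)c3OC)C2=O)cc1OC` gives 14900 nM. Compound 3 `COc1ccc(/C=C2\CCC/C(=C\c3ccccc3Cl)C2=O)cc1OC` gives 21600 nM, and this value lies within the usual scatter of the value for compound 2, so the two numbers cannot be separated.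

Compound 4 `COc1ccc(/C=C2\CCC/C(=C\c3ccc(Cl)cc3)C2=O)cc1OC` has not been measured yet. It carries 4-chlorophenyl in place of the 2-chlorophenyl of compound 3, on a double-bonded chain carbon bound to a double-bonded ring carbon: 4-chlorophenyl in place of 2-chlorophenyl on a double-bonded chain carbon bound to a double-bonded ring carbon. Among the compounds with values here, no two measured compounds differ in one place only, so no measured step bears on this change.

In this assay, the expectation therefore starts from compound 3 at 21600 nM, and no step beyond the scatter is expected. The expected step, a 1.1-fold lower number from compound 3 to compound 4 (0.03 log units; within the scatter), is estimated to stay within the scatter. For compound 4 the expected value is 20000 nM, with an estimated range from 9000 nM to 45000 nM.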

Compound 4, half-maximal inhibitory concentration: 11200 nM
Beside the measured number, compound 4's estimate is 1.8-fold (0.25 log units) above it; measured number inside the range.
By their numbers in this assay, from the lowest: compounds 4, 2 and 3 (each within the scatter of the next). At a limit, above all of these: compound 1.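

In this assay, within the data shown here, this is the first pair that differs in one place only: 4-chlorophenyl in place of 2-chlorophenyl, on a double-bonded chain carbon bound to a double-bonded ring carbon, gives a 1.9-fold lower number from compound 3 to compound 4 (0.29 log units; within the scatter). On this single pair, the two chlorophenyl groups therefore cannot be told apart at this place, and the exchange gives no step beyond the scatter. Nothing measured for these compounds speaks to a cause for this step.

Still open, from the compounds shown here alone, is whether a group other than a chlorophenyl at this place, such as a phenyl carrying a dimethylamino group or a carboxylic acid, would give a step beyond the scatter. Also open, going by these compounds, is whether the same exchange of chlorophenyl groups would read the same with a different substituent pattern on the other aromatic ring of the shared core.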